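The compounds below may be only part of what the source reports. "The series", "measured", "known", "first", "only" and "open" are said of these compounds alone.

Measured so far in a functional assay on V79 cells (Cricetulus griseus) for cytotoxicity, read by colony formation; a lower number here means a stronger inhibitor, a higher number a weaker inhibitor:
compound 1, `NC1CCCN(c2c(F)cc3c(=O)c(C(=O)O)cn(C4CC4)c3c2Cl)C1`, gives 24 ug/mL.
compound 2, `NC1CCCN(c2c(F)cc3c(=O)c(C(=O)O)cn(C4CC4)c3c2C(F)(F)F)C1`, gives only a limit of the assay, not a number: > 500 ug/mL.
compound 3, `CC1CN(c2c(F)cc3c(=O)c(C(=O)O)cn(C4CC4)c3c2Cl)CCN1`, gives 45 ug/mL.

Compound 1 and compound 3 share the same atoms joined differently, and the difference between their cores is 3-methylpiperazin-1-yl in place of 3-aminopiperidin-1-yl on an aromatic carbon. In this assay that change gave a 1.9-fold higher number from compound 1 to compound 3 (0.27 log units; within the scatter). Compound 1 and compound 2 differ by trifluoromethyl in place of chloro on an aromatic carbon. That change gave an at least 20-fold higher number from compound 1 to compound 2 (1.31 log units; beyond the scatter), with compound 2 sitting at the limit of > 500 ug/mL in this assay, at which 1 of the 3 values shown sits. Compound 4, `CC1CN(c2c(F)cc3c(=O)c(C(=O)O)cn(C4CC4)c3c2C(F)(F)F)CCN1`, has not yet been measured. It differs from compound 3 by trifluoromethyl in place of chloro on an aromatic carbon, which is the same kind of change as that from compound 1 to compound 2; the surroundings differ only in that the place is ortho to a 3-methylpiperazin-1-yl group rather than to a 3-aminopiperidin-1-yl group. On the strength of the step of an at least 20-fold higher number from compound 1 to compound 2 (1.31 log units; beyond the scatter) seen on the core of compound 1, the expected step is a 16-fold higher number from compound 3 to compound 4 (1.19 log units; beyond the scatter). Compound 4 is therefore estimated to give about 700 ug/mL, most likely between 250 ug/mL and 3000 ug/mL, and the assay may well report only a limit.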

Compound 4, half-maximal inhibitory concentration: 220 ug/mL
Compound 4: the middle estimate sits 3.2-fold (0.50 log units) above what was measured; measured number outside the range, below it.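

In this assay, trifluoromethyl in place of chloro again gives a weaker inhibitor, here with a 4.9-fold higher number from compound 3 to compound 4 (0.69 log units; beyond the scatter), so the direction of the change carries from one core to the other but its size does not: the same change on two cores in this assay, an at least 20-fold higher number (1.31 log units; beyond the scatter) from compound 1 to compound 2 and a 4.9-fold higher number (0.69 log units; beyond the scatter) from compound 3 to compound 4, at least 4.2-fold (0.62 log units) apart, beyond the scatter of two such steps

The other change, 3-methylpiperazin-1-yl in place of 3-aminopiperidin-1-yl, also depends on its surroundings, here with an at least 2.2-fold lower number from compound 2 to compound 4 (0.35 log units; beyond the scatter): the same change on two cores in this assay, a 1.9-fold higher number (0.27 log units; within the scatter) from compound 1 to compound 3 and an at least 2.2-fold lower number (0.35 log units; beyond the scatter) from compound 2 to compound 4, at least 4.2-fold (0.62 log units) apart, beyond the scatter of two such steps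

Compound 2 gives only a limit of the assay, > 500 ug/mL, so the true gap between the steps remains unknown, and these four compounds show that the two changes depend on each other without showing why.

The compounds shown leave open whether this holds for other groups in place of the chloro, such as a methyl, methoxy or nitrile group. They also leave open how a plain piperazine or an open-chain amine such as dimethylamino would behave in place of the 3-methylpiperazin-1-yl group.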